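The compounds below may be only part of what the source reports. "The series", "measured", "known", "first", "only" and "open" are said of these compounds alone.

Compound 1 `C=C1C(=O)O[C@H]2CC3=C[C@H](C/C(C)=C/[C@@H](OC(=O)CCl)[C@H]12)OC3=O` gives > 10000 nM in a functional assay on NCI-H460 cells (Homo sapiens) for cytotoxicity, read by MTT assay, with a stated time of 48 h (a lower number here means a stronger inhibitor, a higher number a weaker inhibitor), and this is a limit, not a number. Going by the values given here, compound 2 `C=C1C(=O)O[C@H]2CC3=C[C@H](C/C(C)=C/[C@@H](OC(=O)CC(C)C)[C@H]12)OC3=O` gives 3800 nM in this assay, the only actual number so far, so it cannot yet be ranked against a second measured value. Compound 3 `C=C1C(=O)O[C@H]2CC3=C[C@H](C/C(C)=C/[C@@H](OC(=O)/C=C/c4cccs4)[C@H]12)OC3=O` keeps the shared core and changes the ester chain, with 2-(thiophen-2-yl)ethenyl in place of isobutyl on a carbonyl carbon. Among the compounds with values here, the only measured step that bears on this change is an at least 2.6-fold lower number from compound 1 to compound 2 (0.42 log units; beyond the scatter), where isopropyl replaces chloro on a saturated chain carbon bound to a carbonyl carbon. That step shows the number can move with the ester chain, but it is a different swap, so no step beyond the scatter is expected in this assay. The estimated change is a 1.5-fold lower number from compound 2 to compound 3 (0.18 log units; within the scatter). For compound 3 the expected value is 2500 nM, with an estimated range of 700 nM to 9000 nM.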

Compound 3, half-maximal inhibitory concentration: 2900 nM
Beside the measured number, compound 3's estimate is 1.2-fold (0.06 log units) below it; measured number inside the range.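

In this assay, the ester chain on this carbonyl carbon accepts a bigger group than isobutyl without a clear shift: 2-(thiophen-2-yl)ethenyl brings an aromatic ring and a double bond outside it, yet the result is a 1.3-fold lower number from compound 2 to compound 3 (0.12 log units; within the scatter). Set against the chloromethyl chain, the same group gives an at least 3.4-fold lower number from compound 1 to compound 3 (0.53 log units; beyond the scatter), so two quite different chains now stand apart from chloromethyl, not just one. That step is only a minimum, because compound 1 stands at a limit and not at a number: the limit of > 10000 nM in this assay, at which 1 of the 3 values shown sits.

On these data alone, whether an ester chain carrying an amine or a carboxylic acid would hold this level remains open, as does the effect of a phenyl ring in place of the thiophen-2-yl ring. The compounds shown also cannot separate the ring from the double bond, since both enter together.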